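Swapping a branched phenyl chain for a pyridine methylene

This account rests on a few compounds, and the source may have more. Where it says the series, first, only, none or still open, it means among the compounds named here.

Of the compounds shown here, three built on a shared core have been tested so far. Compound 1 `COc1ccc2[nH]c3c(c2c1)CCNC31CCN(Cc2ccc([N+](=O)[O-])cc2F)CC1` gives 5900 nM in an assay on FRT cells for positive allosteric modulation of Cystic fibrosis transmembrane conductance regulator variant N1303K (Homo sapiens), in the presence of a further agent that is not named here; on this read-out lower numbers stand for an effect already at smaller amounts and higher numbers for an effect only at larger amounts of compound. Compound 2 `COc1ccc2[nH]c3c(c2c1)CCNC31CCN(Cc2ccc(Cl)cc2Cl)CC1` gives 1800 nM, and compound 3 `COc1ccc2[nH]c3c(c2c1)CCNC31CCN(C(C)c2ccccc2)CC1` gives 20000 nM. Compound 3 therefore stands at the highest number of the three: the measured step is an 11-fold higher number from compound 2 to compound 3 (1.05 log units; beyond the scatter), and its value also lies well above that of compound 1, so it is the weakest of the set.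

The next compound, compound 4 `COc1ccc2[nH]c3c(c2c1)CCNC31CCN(Cc2ccccn2)CC1`, differs from compound 3 in one place: (pyridin-2-yl)methyl in place of 1-phenylethyl on an amine nitrogen in a ring. Going by the values given here, two measured steps bear on this. The first, a 3.3-fold lower number from compound 1 to compound 2 (0.52 log units; beyond the scatter), shows that exchanging one aryl group for another on this methylene-linked position moves the number modestly. The second, an 11-fold higher number from compound 2 to compound 3 (1.05 log units; beyond the scatter), shows that moving from a methylene-linked aryl group to a branched 1-phenylethyl group raised the number strongly. Compound 4 returns to a methylene-linked aryl group, so a lower number than compound 3 is expected, but no substituted aryl comparable to compound 2 is present, so the expected step is a 4.0-fold lower number from compound 3 to compound 4 (0.60 log units; beyond the scatter). For compound 4 the estimated value in this assay is 5000 nM, with a range from 1500 nM to 20000 nM.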

Compound 4, half-maximal effective concentration: 11500 nM
Estimate against measurement, compound 4: 2.3-fold (0.36 log units) below, and the stated range covers the measured number.
By their numbers in this assay, from the lowest: compound 2; then compounds 1, 4 and 3 (each within the scatter of the next, the first and the last beyond it).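

In this assay the exchange on the amine nitrogen gives a 1.7-fold lower number from compound 3 to compound 4 (0.24 log units; within the scatter) and so does not separate (pyridin-2-yl)methyl from 1-phenylethyl, even though the two groups differ both in the branch on the chain carbon and in the ring nitrogen. Returning to a methylene link therefore does not by itself bring the number close to that of compound 2, as the measured 6.4-fold higher number from compound 2 to compound 4 (0.81 log units; beyond the scatter) shows, while the comparison with the nitro-bearing aryl group gives a 1.9-fold higher number from compound 1 to compound 4 (0.29 log units; within the scatter) and leaves those two groups unseparated. Among compounds 1, 2 and 4, which all carry an aryl group on this methylene link, the 2,4-dichlorophenyl group of compound 2 alone stands apart, and nothing measured here accounts for that difference.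

Since compound 3 and compound 4 differ in two features at once, a plain benzyl group would be needed to tell the effect of the branch from that of the ring nitrogen. Going by these compounds, it also remains open how a single chlorine on the benzyl ring, or a chlorine on the pyridine ring of compound 4, would compare with the 2,4-dichlorobenzyl group of compound 2.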